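From Piperidin-1-yl to (3-Chloro-4-fluorophenyl)amino

The source may hold more compounds than are shown below. What is called first, only, known or untested is meant among the compounds shown, and "the series" means these compounds.

In a functional assay on HGC-27 cells (Homo sapiens) for cytotoxicity, read by MTT assay, with a stated time of 72 h (on this read-out lower numbers stand for stronger inhibition and higher numbers for weaker inhibition), compound 1 `FC(F)(F)c1ccc(CSc2nc(N3CCCCC3)c3ccccc3n2)cc1` registers only > 50000 nM, which is a limit of the assay and not a number. Compound 2 `Fc1ccc(Nc2nc(SCc3ccc(C(F)(F)F)cc3)nc3ccccc23)cc1` gives 19500 nM in this assay. Compound 3 `COc1ccc(Nc2nc(SCc3ccc(C(F)(F)F)cc3)nc3ccccc23)cc1OC` gives 17900 nM in this assay. The step of an at least 2.5-fold lower number from compound 1 to compound 2 (0.40 log units; beyond the scatter) and the step of an at least 2.7-fold lower number from compound 1 to compound 3 (0.44 log units; beyond the scatter) both show lower numbers once the piperidin-1-yl gives way to a (4-fluorophenyl)amino or a (3,4-dimethoxyphenyl)amino group, while the step of a 1.1-fold lower number from compound 2 to compound 3 (0.04 log units; within the scatter) shows the two arylamino variants lying together. Compound 4 `Fc1ccc(Nc2nc(SCc3ccc(C(F)(F)F)cc3)nc3ccccc23)cc1Cl` differs from compound 1 by (3-chloro-4-fluorophenyl)amino in place of piperidin-1-yl on an aromatic carbon. This change parallels the two measured steps from compound 1, and a lowered number is expected for compound 4, of the order of an at least 3.1-fold lower number from compound 1 to compound 4 (0.49 log units; beyond the scatter). Because compound 1 sits at the limit of > 50000 nM in this assay, at which 1 of the 3 values shown sits, the true size of that step cannot be fixed. Compound 4 is estimated at 16000 nM in this assay, with a range from 6000 nM to 45000 nM.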

Compound 4, half-maximal inhibitory concentration: 14700 nM
Beside the measured number, compound 4's estimate is 1.1-fold (0.04 log units) above it, within the range that was stated.
By their numbers in this assay, from the lowest: compounds 4, 3 and 2 (each within the scatter of the next). At a limit, above all of these: compound 1.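

In this assay, (3-chloro-4-fluorophenyl)amino in place of piperidin-1-yl gives an at least 3.4-fold lower number from compound 1 to compound 4 (0.53 log units; beyond the scatter), adding a third arylamino group that stands clear of compound 1 at this aromatic carbon. The value of compound 1 is a limit of the assay and not a number, which leaves the size of that step open: the limit of > 50000 nM in this assay, at which 1 of the 4 values shown sits. What is new is that chloro in place of hydrogen on the phenyl ring gives only a 1.3-fold lower number from compound 2 to compound 4 (0.12 log units; within the scatter), and the change of the whole aryl group gives a 1.2-fold lower number from compound 3 to compound 4 (0.09 log units; within the scatter), leaving compounds 2, 3 and 4 unseparated.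

All three arylamino groups bring both an aromatic ring and a hydrogen-bond donor, and the compounds shown do not tell these two apart. A cyclohexylamino or an N-methyl-N-phenylamino group at this position would bear on that question.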